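Pyridin-3-yl for thiophen-3-yl: one change, two cores

This account rests on a few compounds, and the source may have more. Where it says the series, first, only, none or still open, it means among the compounds named here.

Compound 1, `O=C(/C=C/c1cn(-c2ccccc2)nc1-c1ccsc1)c1ccccc1`, gives 5100 nM in a functional assay on HCT-116 cells (Homo sapiens) for inhibition, read by sulforhodamine B assay, with a stated time of 72 h; on this read-out lower numbers stand for stronger inhibition and higher numbers for weaker inhibition.
Compound 2, `COc1ccc(C(=O)/C=C/c2cn(-c3ccccc3)nc2-c2ccsc2)c(OC)c1OC`, gives 5800 nM in this assay.
Compound 3, `O=C(/C=C/c1cn(-c2ccccc2)nc1-c1cccnc1)c1ccccc1`, gives 2000 nM in this assay.

Compounds 1 and 3 differ in one place only: pyridin-3-yl in place of thiophen-3-yl on an aromatic carbon. That change brought a 2.6-fold lower number from compound 1 to compound 3 (0.41 log units; beyond the scatter), a step that lies beyond the usual scatter of this kind of measurement. Compound 2 shares the thiophen-3-yl group of compound 1 but differs from it in more than one place, and the difference between the two cores is not broken down here. Its number in this assay sits close to that of compound 1, within the scatter, so no order between the two can be read from the data.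

Compound 4, `COc1ccc(C(=O)/C=C/c2cn(-c3ccccc3)nc2-c2cccnc2)c(OC)c1OC`, has not yet been measured. It stands to compound 2 as compound 3 stands to compound 1: pyridin-3-yl in place of thiophen-3-yl on an aromatic carbon. The surroundings of the change are described in the same words for both pairs, so this is the same change on a second core. If it acts as it did before, compound 4 is expected to show a 2.6-fold lower number from compound 2 to compound 4 (0.42 log units; beyond the scatter) in this assay, set beside a 2.6-fold lower number from compound 1 to compound 3 (0.41 log units; beyond the scatter), because compound 2 starts from 5800 nM. Within the data shown here, only one earlier example supports this, so the range is kept wide. Compound 4 is therefore estimated at 2200 nM in this assay, expected to fall between 1000 nM and 5000 nM.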

Compound 4, half-maximal inhibitory concentration: 1100 nM
Beside the measured number, compound 4's estimate is 2.0-fold (0.30 log units) above it; the measured number falls inside the stated range.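

In this assay, putting pyridin-3-yl in place of thiophen-3-yl on the core of compound 2 gave a 5.3-fold lower number from compound 2 to compound 4 (0.72 log units; beyond the scatter), so the change lowered the number here as it did on the core of compound 1. Set side by side, the two steps point the same way and their sizes cannot be told apart: the same change on two cores in this assay, a 2.6-fold lower number (0.41 log units; beyond the scatter) from compound 1 to compound 3 and a 5.3-fold lower number (0.72 log units; beyond the scatter) from compound 2 to compound 4, 2.1-fold (0.32 log units) apart, within the scatter of two such steps

This shows that, in this small set, the change carried over from one core to the other in direction, and that its size on the first core was a fair guide to its size on the second. It does not show that the step is truly larger on the core of compound 2, that the change would act the same way on a third core, or why either step occurs, since two pairs in a single cell assay can show only that the results agree.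

The compounds shown leave open whether the same place would also accept pyridin-4-yl, furan-3-yl or a simple amine. Among these compounds, they also leave open how much each methoxy group on the core of compound 2 contributes, as no pair here isolates one of them.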